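Methyl on the benzylic carbon of compound 2

This account rests on a few compounds, and the source may have more. Where it says the series, first, only, none or still open, it means among the compounds named here.

Measured so far:
compound 1 `C[C@@H](NCC1CCN(CCCc2c[nH]c3ccc(-n4cnnc4)cc23)CC1)c1ccccc1` — 1.4 nM
compound 2 `c1ccc(CNC2CCN(CCCc3c[nH]c4ccc(-n5cnnc5)cc34)CC2)cc1` — 4.6 nM

Going by the values given here, in an assay on CHO cells for displacement of a labelled ligand from 5-hydroxytryptamine receptor 1D (Homo sapiens) (a lower number here means a stronger inhibitor, a higher number a weaker inhibitor), compound 2 gives the highest of the two numbers; its nearest neighbour is compound 1, and the only step available is a 3.3-fold higher number from compound 1 to compound 2 (0.52 log units; beyond the scatter), which combines a shorter link to the saturated ring with loss of the methyl on the benzylic carbon. Compound 3 `C[C@@H](NC1CCN(CCCc2c[nH]c3ccc(-n4cnnc4)cc23)CC1)c1ccccc1` differs from compound 2 by methyl in place of hydrogen on a saturated chain carbon bound to an amine nitrogen and an aromatic carbon, so it puts the methyl of compound 1 back while keeping the shorter link of compound 2. Among the compounds with values here, the step from compound 1 to compound 2 is the only bearing on this change and it is modest; part of it may belong to the methyl, part to the link, and the data do not separate the two. A modest decrease in number is therefore expected for compound 3, as a 1.8-fold lower number from compound 2 to compound 3 (0.26 log units; within the scatter). Compound 3 is estimated at 2.5 nM, within 1 nM to 7 nM.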

Compound 3, half-maximal inhibitory concentration: 0.4 nM
For compound 3 the middle estimate is 6.3-fold (0.80 log units) above the measured one; measured number outside the range, below it.
By their numbers in this assay, from the lowest: compound 3; then compound 1; then compound 2.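

In this assay benzyl to 1-phenylethyl gives a 12-fold lower number from compound 2 to compound 3 (1.06 log units; beyond the scatter) with the link held fixed, so the methyl alone accounts for a large step at this carbon, and the earlier comparison could not isolate it. With the methyl held, (1-phenylethyl)amino in place of ((1-phenylethyl)amino)methyl gives a 3.5-fold lower number from compound 1 to compound 3 (0.54 log units; beyond the scatter) in the same direction, so the shorter link goes with the lower number here, even though a 3.3-fold higher number from compound 1 to compound 2 (0.52 log units; beyond the scatter) runs the other way with the methyl lost as well. The data give no reason for the size of either step.

The benzylaminomethyl partner, which would show the link change without the methyl, is absent from the compounds shown. Also open, from the compounds shown here alone, is whether the mirror-image 1-phenylethyl group, or an ethyl in place of the methyl, would hold the low number of compound 3.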